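The compounds below may be only part of what the source reports. "The series", "measured", "known", "first", "only" and "open" are said of these compounds alone.

Measured so far, in a functional assay on HEK293 cells for negative allosteric modulation of metabotropic glutamate receptor 5 (Homo sapiens), read by HTRF and inositol phosphate accumulation; on this read-out lower numbers stand for stronger inhibition and higher numbers for weaker inhibition:

compound 1 `CCCN(Cc1cnc(Nc2ccc(C)nc2)c(Cl)c1)C(=O)c1nccs1`, 584 nM
compound 2 `CCC[C@H](NC(=O)c1nccs1)c1cnc(Nc2ccc(C)nc2)c(Cl)c1`, 978 nM
compound 3 `CCCC[C@@H](NC(=O)c1nccs1)c1cnc(Nc2ccc(C)nc2)c(Cl)c1`, 30.9 nM

Compound 3 stands lowest of the three numbers in this assay. The nearest to it is compound 1, whose value 584 nM lies beyond the scatter; furthest is compound 2, whose value 978 nM lies beyond the scatter as well. Compound 3 is therefore the most potent of the three.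

Compound 4 `Cc1ccc(Nc2ncc([C@H](NC(=O)c3nccs3)C(C)C)cc2Cl)cn1` has not yet been measured in this assay. It differs from compound 3 in one place: isopropyl in place of butyl on a saturated chain carbon bound to an amide-type nitrogen and an aromatic carbon. For the measured compounds named here, no step between measured compounds matches this change, so the expectation rests on the numbers alone. Compound 2, carrying a shorter chain at the same kind of carbon, gives 978 nM, and compound 3 gives 30.9 nM; a smaller group at this carbon is thus expected to cost potency in compound 4, though with a branched group the size of that cost is uncertain. The estimated step from compound 3 to compound 4 is a 4.9-fold higher number from compound 3 to compound 4 (0.69 log units; beyond the scatter). Compound 4 is expected to give 150 nM, in the range 40 nM to 600 nM.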

Compound 4, half-maximal inhibitory concentration: 7.5 nM
Compound 4: the middle estimate sits 20-fold (1.30 log units) above what was measured; measured number below the stated range.
By their numbers in this assay, from the lowest: compound 4; then compound 3; then compounds 1 and 2 (each within the scatter of the next).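

In this assay, isopropyl in place of butyl on a saturated chain carbon bound to an amide-type nitrogen and an aromatic carbon gives a 4.1-fold lower number from compound 3 to compound 4 (0.61 log units; beyond the scatter). For the compounds shown here, this is the first direct one-place comparison at this carbon, and it shows that, for this pair, the branched group with fewer carbons does not cost inhibition but strengthens it beyond the usual scatter. No measurement shown explains why the number falls with this change.

With only butyl and isopropyl compared directly, the compounds shown cannot separate the effect of branching from that of chain length. They also leave open how a cyclopropyl, a tert-butyl or a longer chain on this carbon would read in this assay.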